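The source may report more compounds than this note shows. Statements on the series, on what has been measured and on what is new or still open speak of the compounds shown alone.

Measured compounds, with their results in a functional assay on HT-29 cells (Homo sapiens) for antiproliferative activity, read by MTT assay, with a stated time of 72 h; on this read-out higher numbers stand for weaker inhibition of growth and lower numbers for stronger inhibition of growth:
Compound 1 `Cc1ccc2nc(-c3ccc(N(Cc4ccccc4)Cc4ccccc4)cc3)cn2c1` gives 37600 nM.
Compound 2 `Cc1ccn2cc(-c3ccc(N)cc3)nc2c1` gives 93600 nM.
Compound 3 `Cc1ccn2cc(-c3ccc(NCc4ccccc4)cc3)nc2c1` gives 17500 nM.

Compound 3 stands lowest of the three in this assay; compound 1 is nearest to it, and compound 2 furthest.

Compound 4 `Cc1ccn2cc(-c3ccc(N(Cc4ccccc4)Cc4ccccc4)cc3)nc2c1` has not yet been measured. It differs from compound 3 by benzyl in place of hydrogen on a nitrogen on an aromatic ring, so the nitrogen that in compound 3 carries one benzyl and one hydrogen carries two benzyls in compound 4.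

Going by the values given here, one measured step bears on this change: a 5.3-fold lower number from compound 2 to compound 3 (0.73 log units; beyond the scatter). That step put a benzyl onto the same nitrogen, starting from a nitrogen with two hydrogens. Among the compounds with values here, compound 1 carries two benzyls on this nitrogen, as compound 4 does, but on a core that differs from the shared core of compounds 2, 3 and 4, so no step between compound 1 and any of them is counted; what the values show is that compound 1 sits higher than compound 3 in this assay.

On that basis a second benzyl is expected to give a step near the scatter, if anything a somewhat higher number, so that for compound 4 the expected step is a 1.4-fold higher number from compound 3 to compound 4 (0.15 log units; within the scatter). The estimated value for compound 4 in this assay is 25000 nM, with a range from 8000 nM to 80000 nM.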

Compound 4, concentration for 50% growth inhibition: 6900 nM
Estimate against measurement, compound 4: 3.6-fold (0.56 log units) above, and the stated range ends above it.
By their numbers in this assay, from the lowest: compound 4; then compound 3; then compound 1; then compound 2.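

In this assay, adding a second benzyl to the nitrogen continues the direction set by the first (first benzyl: a 5.3-fold lower number from compound 2 to compound 3 (0.73 log units; beyond the scatter); second benzyl: a 2.5-fold lower number from compound 3 to compound 4 (0.40 log units; beyond the scatter)), so replacing the remaining hydrogen still lowers the number and the series does not turn upward at the doubly benzylated nitrogen. The core matters as well: with two benzyls on the nitrogen in both compounds, changing the core of compound 1 to the shared core gives a 5.4-fold lower number from compound 1 to compound 4 (0.74 log units; beyond the scatter), so the high number of compound 1 cannot be read as a mark against the second benzyl. Nothing presented here explains why either change lowers the number in this assay.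

The compounds shown leave open whether the lower numbers depend on the benzyl group itself, or whether a methyl group or a longer chain such as phenethyl on this nitrogen would do the same. They also leave open how a single benzyl would behave on the core of compound 1, and so whether the steps seen on the shared core carry over to that core.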